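Methoxy for hydroxy on the anilino ring of the nitro-furazan series

The compounds below may be only part of what the source reports. "The series", "measured", "known", "first", "only" and "open" are said of these compounds alone.

Measured so far:
compound 1 `O=[N+]([O-])c1ccc(Nc2ccccc2)c2nonc12`: 2%
compound 2 `O=[N+]([O-])c1ccc(Nc2ccccc2O)c2nonc12`: 13%

Going by the values given here, in an assay on isolated protein for inhibition of Myc proto-oncogene protein (Homo sapiens), read by mobility shift assay, tested at 100 uM (on this read-out lower numbers stand for less inhibition and higher numbers for more inhibition at the one concentration tested (going by the name of the read-out)), compound 2 gives the higher of the two numbers; compound 1 sits a number 11 percentage points higher from compound 1 to compound 2 (beyond the scatter) away, with hydroxy in place of hydrogen on an aromatic carbon as the only change. Compound 3 `COc1ccccc1Nc1ccc([N+](=O)[O-])c2nonc12` follows from compound 2 by methyl in place of hydrogen on an oxygen on an aromatic ring. Among the compounds with values here, no measured step shows this change; the only measured step concerns the hydroxy itself, and it was modest. The expected step of a number 6 percentage points lower from compound 2 to compound 3 (within the scatter) is therefore small, leaning downward, hardly beyond the scatter. Compound 3 is estimated at 7% (range -2% to 18%).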

Compound 3, a percentage reported as inhibition, at one concentration (the size of the read-out at that concentration, not a potency): 0%
For compound 3 the middle estimate is 7 percentage points above the measured one; the range from low to high includes it.
By their numbers in this assay, from the lowest: compounds 3 and 1 (each within the scatter of the next); then compound 2.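

In this assay, methylating the oxygen cancels the gain seen with the hydroxy, giving a number 13 percentage points lower from compound 2 to compound 3 (beyond the scatter) in this series. Methoxy in place of hydrogen on the aromatic carbon gives a number 2 percentage points lower from compound 1 to compound 3 (within the scatter) and no separation from the unsubstituted ring, so among these compounds only the free hydroxy goes with the higher number. No available data bear on the reason for this difference. Going by these compounds, it remains open whether an amine or a carboxylic acid at this position would match the hydroxy, and whether a longer chain on the oxygen would behave like methoxy.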